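Methoxy Additions and Fibroblast Cytotoxicity in a Shared Core

This account rests on a few compounds, and the source may have more. Where it says the series, first, only, none or still open, it means among the compounds named here.

Compound 1, `COc1ccccc1/C=C1\CCC/C(=C\c2ccc(OC)c(OC)c2)C1=O`: 18100 nM in an ADME assay on NHDF cells (Homo sapiens) for cytotoxicity, read by MTT assay, with a stated time of 72 h; on this read-out lower numbers stand for stronger inhibition and higher numbers for weaker inhibition.
Compound 2, `COc1ccc(/C=C2\CCC/C(=C\c3ccc(OC)c(OC)c3)C2=O)c(OC)c1`: in this assay only a limit is reported for compound 2, > 50000 nM.
Compound 3, `COc1cc(/C=C2\CCC/C(=C\c3ccc(OC)c(OC)c3)C2=O)cc(OC)c1`: 6500 nM.

Compound 3 stands lowest of the two numbers given; the difference between its core and the core of compound 1 is not broken down here. The change methoxy in place of hydrogen on an aromatic carbon gives an at least 2.7-fold higher number from compound 1 to compound 2 (0.44 log units; beyond the scatter), and the same kind of change appears again going to compound 4, `COc1ccc(/C=C2\CCC/C(=C\c3cc(OC)c(OC)c(OC)c3)C2=O)cc1OC`, which differs from compound 3 by methoxy in place of hydrogen on an aromatic carbon. The surroundings are not identical: in compound 2 the entering methoxy sits meta to a methoxy group and para to a large group, while in compound 4 it sits ortho to two methoxy groups and para to a large group. Resting on the step from compound 1 to compound 2, a weakening is expected, a 2.2-fold higher number from compound 3 to compound 4 (0.33 log units; beyond the scatter). Compound 4 is estimated at 14000 nM, somewhere between 5000 nM and 45000 nM.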

Compound 4, half-maximal inhibitory concentration: 5800 nM
Compound 4: middle estimate off by 2.4-fold (0.38 log units), on the high side; measured number inside the range.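

In this assay the methoxy in place of hydrogen on an aromatic carbon gives a 1.1-fold lower number from compound 3 to compound 4 (0.05 log units; within the scatter) and does not repeat the earlier rise, so the change did not carry over between these two cores: the same change on two cores in this assay, an at least 2.7-fold higher number (0.44 log units; beyond the scatter) from compound 1 to compound 2 and a 1.1-fold lower number (0.05 log units; within the scatter) from compound 3 to compound 4, at least 3.0-fold (0.49 log units) apart, beyond the scatter of two such steps

Compound 2 stands at a limit of the assay and not at a number, which leaves the earlier step bounded on one side only: the limit of > 50000 nM in this assay, at which 1 of the 4 values shown sits.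

The two steps show that the result of this change on one core cannot be assumed for the other here, but they cannot show whether the different surroundings of the entering methoxy or some other part of the cores lie behind the gap, nor how the change would read on any further core.

The compounds shown leave open how a hydroxy group, an amine or a carboxylic acid would read in the place taken by the entering methoxy. They also leave open whether a longer chain such as ethoxy in that place would follow compound 2 or compound 4.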